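Swapping the aniline ring: from compound 1 to compound 4

The source may report more compounds than this note shows. Statements on the series, on what has been measured and on what is new or still open speak of the compounds shown alone.

The measured compounds, with their values in a functional assay on NCI-H226 cells (Homo sapiens) for inhibition, read by MTT assay, with a stated time of 48 h, tested at 10 uM; a lower number here means less inhibition, a higher number more inhibition at the concentration tested (going by the name of the read-out):
compound 1, `Cc1ccc(Nc2cc(NC(=O)Nc3c(Cl)cccc3Cl)ncn2)cc1F`, 40.7%
compound 2, `COc1cc(NC(=O)Nc2cc(Nc3cc(C(F)(F)F)ccc3OC)ncn2)cc(OC)c1`, 60%
compound 3, `CCc1cccc(Nc2cc(NC(=O)Nc3cc(OC)cc(OC)c3)ncn2)c1`, 36.7%

Of these three numbers, compound 1 stands second highest. Its nearest neighbour is compound 3, whose value lies within the scatter of compound 1, so the two cannot be ordered. The furthest is compound 2, whose value lies beyond the scatter above compound 1.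

Compound 4, `CCc1ccc(Nc2cc(NC(=O)Nc3c(Cl)cccc3Cl)ncn2)cc1`, has not yet been measured. It differs from compound 1 in one place on the shared core:
4-ethylphenyl in place of 3-fluoro-4-methylphenyl on a nitrogen on an aromatic ring

For the measured compounds named here, no pair of measured compounds differs in this single place, so the step has no measured precedent. Going by the values given here, the 4-ethylphenyl group and the 3-fluoro-4-methylphenyl group are of the same size by the count given, with no change in donors or acceptors, and no pair on record shows that such a swap moves this read-out. Compound 4 is therefore expected to sit close to compound 1, with a step of a number 2.7 percentage points lower from compound 1 to compound 4 (within the scatter) that stays within the scatter. The estimate for compound 4 in this assay is 38%, with a range from 15% to 60%.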

Compound 4, a percentage reported as inhibition, at one concentration (the size of the read-out at that concentration, not a potency): 39.5%
Compound 4: middle estimate off by 1.5 percentage points, on the low side; measured number inside the range.
By their numbers in this assay, from the lowest: compounds 3, 4 and 1 (each within the scatter of the next); then compound 2.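

For the compounds shown here, the first measured step at this place on the shared core reads a number 1.2 percentage points lower from compound 1 to compound 4 (within the scatter) and so the 4-ethylphenyl group and the 3-fluoro-4-methylphenyl group cannot be ordered in this assay at the concentration tested. For this pair, then, the read-out gives no sign that the fluorine of the departing group is needed, although one pair says nothing about other groups on this nitrogen. Nothing measured here accounts for the result.

The compounds shown leave open whether a ring of another kind at this nitrogen, such as a pyridine, or a carboxylic acid or an amine carried on the aniline ring, would move this read-out beyond the scatter. They also leave open whether a plain alkyl chain could stand in place of the aromatic ring.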